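Ortho phenyl in place of bromo on the sulfonyl aryl

The source may hold more compounds than are shown below. What is called first, only, known or untested is meant among the compounds shown, and "the series" means these compounds.

Compound 1 `CC1CCN(C2CCN(S(=O)(=O)c3ccccc3Br)CC2)CC1` is the strongest inhibitor among the numbers shown: in a functional assay on DLD-1 cells (Homo sapiens) for antiproliferative activity, read by CellTiter-Glo, with a stated time of 72 h (a higher number here means a weaker inhibitor, a lower number a stronger inhibitor), compound 1 gives 3 nM. Compound 2 `CC1CCN(C2CCN(S(=O)(=O)c3cnc(Cl)s3)CC2)CC1` gives 1800 nM in this assay, so that a 600-fold higher number from compound 1 to compound 2 (2.78 log units; beyond the scatter). Compound 3 `CC1CCN(C2CCN(S(=O)(=O)c3cccc(Cl)c3)CC2)CC1` reaches only the limit of the assay, > 5000 nM, and not a number; that is the limit of > 5000 nM in this assay, at which 1 of the 3 values shown sits. Accordingly an at least 1600-fold higher number from compound 1 to compound 3 (3.22 log units; beyond the scatter), and an at least 2.7-fold higher number from compound 2 to compound 3 (0.44 log units; beyond the scatter).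

Compound 4 `CC1CCN(C2CCN(S(=O)(=O)c3ccccc3-c3ccccc3)CC2)CC1` differs from compound 1 in one place: phenyl in place of bromo on an aromatic carbon. Going by the values given here, none of the measured steps makes this exact change. The steps from compound 1 to compound 2 and from compound 1 to compound 3 each replace the whole 2-bromophenyl group, and both are large losses; the step from compound 2 to compound 3 is at least modest. They show that the aryl group on the sulfonyl sulfur matters greatly, but they do not say whether a phenyl where the bromo sat, ortho to a large group, keeps the number of compound 1. The estimate therefore leans toward a moderate loss with a wide range, so that a 10-fold higher number from compound 1 to compound 4 (1.00 log units; beyond the scatter) is expected. Compound 4 is estimated at 30 nM, with a range from 3 nM to 400 nM in this assay.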

Compound 4, half-maximal inhibitory concentration: 0.96 nM
Compound 4: the middle estimate sits 31-fold (1.49 log units) above what was measured; the whole stated range lies above it.
By their numbers in this assay, from the lowest: compound 4; then compound 1; then compound 2. At a limit, above all of these: compound 3.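

At this position, on an aromatic carbon ortho to a large group, a much larger substituent is accepted in this assay: phenyl in place of bromo gives a 3.1-fold lower number from compound 1 to compound 4 (0.49 log units; beyond the scatter), a modest step in favour of the larger group. The earlier steps shown here replaced the whole 2-bromophenyl group and so spoke only of the aryl group as a whole, whereas this change keeps that ring and shows that a six-membered aromatic ring of carbon only can stand where a single bromine stood without any loss in the number. Nothing among the data shown gives a cause for this step.

The compounds shown leave open how a methyl group, a methoxy group or a pyridyl ring would read at this place, and whether an amine or a carboxylic acid on the entering phenyl would keep the number of compound 4. They also leave open whether the gain depends on the rest of the core of compound 4, since the change is seen on this one pair alone.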